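The source may report more compounds than this note shows. Statements on the series, on what has been measured and on what is new or still open speak of the compounds shown alone.

Working notes on the series built on the shared core: compound 1 `CCCCCCCCCC(=O)Nc1nc(N)nc2c1ncn2[C@H]1CO[C@@H](CO)O1`, compound 2 `CCCCCCCCCCCC(=O)Nc1nc(N)nc2c1ncn2[C@H]1CO[C@@H](CO)O1` and the unmeasured compound 3 `CCCCCCCCCCCCCC(=O)Nc1nc(N)nc2c1ncn2[C@H]1CO[C@@H](CO)O1`, all read in a functional assay on HepG2 cells (Homo sapiens) for cytotoxicity; a lower number here means that less compound is tolerated, a higher number that more compound is tolerated. Compound 1 gives > 100000 nM, which is a limit of the assay and not a number. Compound 2 gives > 100000 nM, which is likewise a limit and not a number. The position of compound 2 is therefore known only as a limit, and the record so far reads: the limit of > 100000 nM in this assay, at which 2 of the 2 values shown sit.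

The change to compound 3 is ethyl in place of hydrogen on a saturated chain carbon, ten or more bonds along the chain from a carbonyl carbon. For the measured compounds named here, the one measured step bearing on it is a step that the two limits leave unreadable from compound 1 to compound 2, where ethyl replaced hydrogen on a saturated chain carbon, nine bonds along the chain from a carbonyl carbon. That step has no readable size, so it offers only weak guidance. On the strength of that step, no change beyond the scatter is expected in this assay, and a further limit is the likeliest report.

The expected step is a number no higher from compound 2 to compound 3 (the limit leaves the size open).
For compound 3 the estimated value is 100000 nM, with an expected range of 50000 nM to 200000 nM.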

Compound 3, half-maximal cytotoxic concentration: 56000 nM
The estimate for compound 3 lay 1.8-fold (0.25 log units) above the measured number; measured number inside the range.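

In this assay, for the compounds shown here, compound 3 gives 56000 nM, the first true number and not a limit, so ethyl in place of hydrogen on a saturated chain carbon gives a result that can be placed on the scale. The record now reads an at least 1.7-fold lower number from compound 2 to compound 3 (0.25 log units; that floor lies within the scatter), and an at least 1.7-fold lower number from compound 1 to compound 3 (0.25 log units; that floor lies within the scatter); both are floors, and neither by itself establishes a real change in tolerated concentration. The step from compound 1 to compound 2 cannot be read, and the remainder of the record stays at an assay limit: the limit of > 100000 nM in this assay, at which 2 of the 3 values shown sit.

From the compounds shown here alone, whether a longer chain than that of compound 3 would carry the number beyond the scatter remains open, and with it whether the chain series has any real trend in this assay. Also open, going by these compounds, is how an amine or a carboxylic acid would read in place of the ethyl on the same saturated chain carbon.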